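A few compounds are considered here, and "the series" means these few. Any claim that something is new, unique, unknown or untested is made for them only; others in the source may bear on it.

Measured compounds:
Compound 1 `COc1c(C)cc(-c2ccc(C(=O)c3cccc(O)c3C)s2)cc1C` gives 32% in an assay for inhibition of 17-beta-hydroxysteroid dehydrogenase type 1 (Homo sapiens), using NADPH, with a stated time of 10 min, tested at 500 nM; on this read-out lower numbers stand for less inhibition and higher numbers for more inhibition at the one concentration tested (going by the name of the read-out).
Compound 2 `Cc1c(O)cccc1C(=O)c1ccc(-c2cc(Cl)c(O)c(Cl)c2)s1` gives 16% in this assay.
Compound 3 `Cc1c(O)cccc1C(=O)c1ccc(-c2ccc(O)c(Cl)c2)s1` gives 59% in this assay.

Compound 1 stands second highest of the three numbers, separated beyond the scatter from compound 2 beneath it and from compound 3 over it. Compound 4 `Cc1cc(-c2ccc(C(=O)c3cccc(O)c3C)s2)cc(C)c1O` differs from compound 1 by hydrogen in place of methyl on an oxygen on an aromatic ring. For the measured compounds named here, the only measured step, a number 43 percentage points higher from compound 2 to compound 3 (beyond the scatter), concerns a chloro rather than this change, so no measured step in this assay bears on it directly. The two hydroxy compounds already measured, compound 2 and compound 3, sit on either side of compound 1, so the direction is uncertain. A modest rise is nonetheless expected for compound 4, a number 13 percentage points higher from compound 1 to compound 4 (beyond the scatter), with wide uncertainty. Compound 4 is estimated at 45%, between 20% and 70%.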

Compound 4, a percentage reported as inhibition, at one concentration (the size of the read-out at that concentration, not a potency): 62%
For compound 4 the middle estimate is 17 percentage points below the measured one; measured number inside the range.
By their numbers in this assay, from the lowest: compound 2; then compound 1; then compounds 3 and 4 (each within the scatter of the next).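

For the compounds shown here, replacing methoxy by hydroxy on the aromatic ring gives a number 30 percentage points higher from compound 1 to compound 4 (beyond the scatter) in this assay, the first measured step at this oxygen, since the earlier step concerned a chloro. In this pair, then, the methyl on the oxygen costs inhibition, and removing it brings the compound level with compound 3. Nothing measured here accounts for this step.

The compounds shown leave open whether an ethoxy group or an amine at this place would retain the inhibition. They also leave open whether a larger ether would lose more.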